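Methyl to propyl on compound 3

This account rests on a few compounds, and the source may have more. Where it says the series, first, only, none or still open, it means among the compounds named here.

Measured values in a functional assay on the whole organism with Rattus norvegicus as the target (a higher number here means that more compound is needed for the effect, a lower number that less compound is needed), are as follows
- compound 1 `CCCc1ccc2nc(N)sc2c1` gives 6 mg/kg
- compound 2 `CCCCCc1ccc2nc(N)sc2c1` gives 7.5 mg/kg
- compound 3 `Cn1c(=N)sc2cc(OC(F)(F)F)ccc21` gives 5 mg/kg

The value of compound 3 lies within the scatter of the values of compound 1 and compound 2. Compound 4 (`CCCn1c(=N)sc2cc(OC(F)(F)F)ccc21`) has ethyl in place of hydrogen on a saturated chain carbon bound to an aromatic nitrogen, which reads as methyl to propyl (ethyl in place of hydrogen on a saturated chain carbon bound to an aromatic nitrogen). Going by the values given here, the one measured step of this kind (a 1.3-fold higher number from compound 1 to compound 2 (0.10 log units; within the scatter)) also puts ethyl in place of hydrogen, but three bonds along the chain from an aromatic carbon, and it stays within the scatter. No step beyond the scatter is therefore expected in this assay for this change. The expected step (a 1.2-fold higher number from compound 3 to compound 4 (0.08 log units; within the scatter)) is correspondingly small. For compound 4 the estimated value is 6 mg/kg (expected range 3 mg/kg to 12 mg/kg).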

Compound 4, dose for half-maximal effect: 4.5 mg/kg
For compound 4 the middle estimate is 1.3-fold (0.12 log units) above the measured one; the measured number falls inside the stated range.
By their numbers in this assay, from the lowest: compounds 4, 3, 1 and 2 (each within the scatter of the next).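

At the saturated chain carbon bound to an aromatic nitrogen, ethyl in place of hydrogen gives a 1.1-fold lower number from compound 3 to compound 4 (0.05 log units; within the scatter) in this assay, so this position takes a propyl in place of a methyl with no step beyond the scatter. The change now stays within the scatter on a chain at an aromatic nitrogen as well as on one at an aromatic carbon: the same change on two cores in this assay, a 1.3-fold higher number (0.10 log units; within the scatter) from compound 1 to compound 2 and a 1.1-fold lower number (0.05 log units; within the scatter) from compound 3 to compound 4, 1.4-fold (0.14 log units) apart, within the scatter of two such steps.

Open: whether a longer chain on this nitrogen, or a carboxylic acid or an amine at the chain end, gives a step beyond the scatter in this assay.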